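From Methoxy to Methyl on a Shared Core

The source may report more compounds than this note shows. Statements on the series, on what has been measured and on what is new or still open speak of the compounds shown alone.

Of the compounds shown here, three sharing one core have been measured in a functional assay on HeLa cells (Homo sapiens) for antiproliferative activity, read by MTT assay, with a stated time of 48 h; a lower number here means a stronger inhibitor, a higher number a weaker inhibitor. Compound 1 `Clc1ccc(-c2nn(-c3ccccc3)cc2-c2nc3cc(Cl)ccc3[nH]2)cc1` gives 1630 nM, compound 2 `Clc1ccc(-c2nn(-c3ccccc3)cc2-c2nc3cc(Br)ccc3[nH]2)cc1` gives 2160 nM, and compound 3 `COc1ccc2[nH]c(-c3cn(-c4ccccc4)nc3-c3ccc(Cl)cc3)nc2c1` gives 3630 nM. Set against the other two, the numbers show a 2.2-fold higher number from compound 1 to compound 3 (0.35 log units; beyond the scatter) and a 1.7-fold higher number from compound 2 to compound 3 (0.23 log units; within the scatter), so compound 3 stands clearly apart from only one of them.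

Compound 4 `Cc1ccc2[nH]c(-c3cn(-c4ccccc4)nc3-c3ccc(Cl)cc3)nc2c1` has not yet been measured. It differs from compound 3 in one group, with methyl in place of methoxy on an aromatic carbon.

Going by the values given here, no measured pair makes this exact exchange, so the evidence is indirect. The closest guide is the set of steps among the three groups already tested at this place. These are a 1.3-fold higher number from compound 1 to compound 2 (0.12 log units; within the scatter), together with the two steps that involve methoxy. The largest of them is a 2.2-fold higher number from compound 1 to compound 3 (0.35 log units; beyond the scatter), and that one is only modest. On that basis, no step beyond the scatter is expected in this assay, and no direction can be firmly predicted. The expected outcome is a 1.3-fold lower number from compound 3 to compound 4 (0.11 log units; within the scatter), which would keep compound 4 among its measured relatives. For compound 4, the estimated value is 2800 nM, with an expected range from 1400 nM to 5500 nM.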

Compound 4, half-maximal inhibitory concentration: 5360 nM
Beside the measured number, compound 4's estimate is 1.9-fold (0.28 log units) below it; low and high end bracket the measured number.
By their numbers in this assay, from the lowest: compounds 1, 2, 3 and 4 (each within the scatter of the next, the first and the last beyond it).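

The exchange of methoxy for methyl gives a 1.5-fold higher number from compound 3 to compound 4 (0.17 log units; within the scatter), so in this assay these two groups cannot be told apart at this aromatic carbon. Methyl can be told apart from both halogens, with a 2.5-fold higher number from compound 2 to compound 4 (0.39 log units; beyond the scatter) and a 3.3-fold higher number from compound 1 to compound 4 (0.52 log units; beyond the scatter), whereas methoxy stood clear only of chloro and remained within the scatter of bromo, as a 1.7-fold higher number from compound 2 to compound 3 (0.23 log units; within the scatter) shows; the four groups therefore form a chain in which chloro and methyl lie at opposite ends, and the step between these two is the largest seen so far at this position. Nothing measured for these compounds explains why the groups differ in this way.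

On these data alone, all four compounds carry chloro, bromo, methoxy or methyl at this one place, so it remains open whether a hydroxyl group, an amine or a carboxylic acid there would fall inside this narrow spread or outside it. Every change shown also sits at this single position on the shared core, which leaves open whether the same order of groups would hold if the core's other rings were changed.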